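Hydroxy to Methoxy: Expecting No Gain in Potency

The compounds below may be only part of what the source reports. "The series", "measured", "known", "first", "only" and "open" are said of these compounds alone.

compound 1, `O=C(Nc1cccc(Cl)c1)c1ccccc1O`: > 100000 nM
compound 2, `COc1ccc(Br)cc1C(=O)Nc1ccccc1`: > 100000 nM

Of the compounds shown here, two have been measured in an assay on isolated protein for inhibition of thiosulfate sulfurtransferase (Homo sapiens), with a stated time of 60 min, in the absence of a further agent; on this read-out higher numbers stand for weaker inhibition and lower numbers for stronger inhibition. In this assay compound 1 gives > 100000 nM, which is a limit of the assay and not a number. Compound 2 in this assay gives > 100000 nM, again a limit rather than a number. Compound 1 therefore stands at the limit, and every value shown sits there: the limit of > 100000 nM in this assay, at which 2 of the 2 values shown sit. Among the measured compounds shown here, no step between two measured compounds can be read, since the pair differ in more than one place and neither gives a number.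

Compound 3, `COc1ccccc1C(=O)Nc1cccc(Cl)c1`, differs from compound 1 by methyl in place of hydrogen on an oxygen on an aromatic ring. For the measured compounds named here, with no measured step available in this assay, neither a direction nor a size of change beyond the scatter of repeated measurements is expected. Compound 3 is expected to show a number no higher from compound 1 to compound 3 (the limit leaves the size open), that is, no movement away from where compound 1 sits. Compound 3 is estimated at 100000 nM, with a range from 30000 nM to 300000 nM, and the most likely outcome is once more a limit.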

Compound 3, half-maximal inhibitory concentration: > 100000 nM
Compound 3 ended at the assay's limit; the forecaster's own chance of this, stated with the estimate: 85%; the middle value sits exactly at the limit.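

Among the compounds shown here, no step from compound 1 to compound 3 can be read in this assay: both stand at a limit of the assay, and neither gives a number. All the values shown lie at that one limit: the limit of > 100000 nM in this assay, at which 3 of the 3 values shown sit.

The compounds shown leave open whether hydroxy to methoxy changes inhibition at all, and what on the shared core would yield a measurable value.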